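A few compounds are considered here, and "the series" means these few. Any claim that something is new, unique, unknown or untested is made for them only; others in the source may bear on it.

Three close relatives of one shared core have been measured in an assay for inhibition of MAP kinase-interacting serine/threonine-protein kinase 1 (Homo sapiens), read by luminescence and ADP-Glo, with a stated time of 2 h; a lower number here means a stronger inhibitor, a higher number a weaker inhibitor. Compound 1, `Nc1n[nH]c2cc(-c3ccc(=O)n(Cc4ccccc4)c3)ccc12`, gives 79 nM. Compound 2, `O=c1ccc(-c2ccc3cn[nH]c3c2)cn1Cc1ccccc1C(F)(F)F`, gives 133 nM. Compound 3, `O=c1ccc(-c2ccc3cn[nH]c3c2)cn1Cc1ccccc1`, gives 315 nM, which is the weakest of the three numbers: its step from compound 1, a 4.0-fold higher number from compound 1 to compound 3 (0.60 log units; beyond the scatter), and its step from compound 2, a 2.4-fold higher number from compound 2 to compound 3 (0.37 log units; beyond the scatter), both lie beyond the scatter, and both come from removing a group on an aromatic carbon.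

Compound 4, `Cn1ncc2ccc(-c3ccc(=O)n(Cc4ccccc4)c3)cc21`, differs from compound 3 in one place: methyl in place of hydrogen on an aromatic nitrogen. Neither measured step touches this ring nitrogen, so nothing seen so far speaks directly to this change; the two steps only show that the core tolerates a change of a small group with a modest shift in this assay. Removing the hydrogen on that ring nitrogen in favour of a methyl is a different kind of change, and the expectation is a weakening step, a 4.8-fold higher number from compound 3 to compound 4 (0.68 log units; beyond the scatter), though its size is uncertain. Compound 4 is therefore estimated at 1500 nM, with a range from 400 nM to 6000 nM.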

Compound 4, half-maximal inhibitory concentration: > 2000 nM
Compound 4: no number, only a limit (the forecaster's own chance of this, stated with the estimate: 15%); middle value at least 1.3-fold (0.12 log units) from the limit.
By their numbers in this assay, from the lowest: compounds 1 and 2 (each within the scatter of the next); then compound 3. At a limit, above all of these: compound 4.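

Placing methyl in place of hydrogen on an aromatic nitrogen gives an at least 6.3-fold higher number from compound 3 to compound 4 (0.80 log units; beyond the scatter), and this is the first change shown at this ring nitrogen. Even at its smallest possible size, this step is larger than the earlier steps, in which compound 3 lost an amino group relative to compound 1 or a trifluoromethyl group relative to compound 2, so in this assay this nitrogen is the most sensitive of the places changed so far. For compound 4, > 2000 nM is a limit and not a number, so the step gives only a lower bound on the loss, and its true size stays unknown: the limit of > 2000 nM in this assay, at which 1 of the 4 values shown sits.

With methyl as the only replacement shown on this nitrogen, the compounds cannot separate the loss of the hydrogen from the presence of the added carbon, and an ethyl group or a longer chain ending in an amine at the same place would be a further test of what it tolerates. From the compounds shown here alone, it also remains open whether the same methyl would weaken the amino-bearing compound 1 or the trifluoromethyl-bearing compound 2 to a similar degree.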